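The source may report more compounds than this note shows. Statements on the series, on what has been measured and on what is new or still open speak of the compounds shown alone.

Measured in a functional assay on L1210 cells (Mus musculus) for cytotoxicity; a lower number here means a stronger inhibitor, a higher number a weaker inhibitor:
- compound 1 `Nc1nc(F)nc2c1ncn2[C@H]1C[C@H](O)[C@@H](CO)O1`: 900 nM
- compound 2 `Nc1nc(Br)nc2c1ncn2C1O[C@H](CO)[C@@H](O)[C@H]1O`: 3000 nM

Of these two numbers, compound 1 900 nM holds the lower, and compound 2 lies above it by more than the usual scatter. The next compound for this assay is compound 3 `Nc1nc(Br)nc2c1ncn2[C@H]1C[C@H](O)[C@@H](CO)O1`, which keeps the core of compound 1 and changes one group: bromo in place of fluoro on an aromatic carbon. The bromo takes the place of fluoro on an aromatic carbon between two ring nitrogen atoms. For the measured compounds named here, no measured pair isolates this exchange, so the data give no direct guide to its size or direction. Without such evidence, the expected step of a 1.1-fold higher number from compound 1 to compound 3 (0.05 log units; within the scatter) is small, with no change beyond the scatter expected. For compound 3 the estimated value is 1000 nM, with an expected range of 300 nM to 3000 nM.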

Compound 3, half-maximal inhibitory concentration: 900 nM
Estimate against measurement, compound 3: 1.1-fold (0.05 log units) above, within the range that was stated.
By their numbers in this assay, from the lowest: compounds 1 and 3 (each within the scatter of the next); then compound 2.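

In this assay, for the compounds shown here, bromo in place of fluoro on the aromatic carbon between two ring nitrogen atoms gives no change at the digits printed from compound 1 to compound 3 (within the scatter), the first direct reading of this position. On the core of compound 1, this assay therefore does not tell these two halogens apart at this carbon, and the exchange of one heavy atom for another leaves the read-out within the scatter. The data at hand offer no explanation for this outcome.

Still open, on these data alone, is how an amine, a methoxy group or plain hydrogen on this carbon would read in this assay, since both groups compared so far are halogens. Also open, as far as these compounds go, is whether the same exchange would read alike on the core of compound 2.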